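Benzyloxy aryl variation in a phenoxyethylamine series

A few compounds are considered here, and "the series" means these few. Any claim that something is new, unique, unknown or untested is made for them only; others in the source may bear on it.

Measured compounds, with their values in a functional assay on spleen for antagonist activity at Alpha-1B adrenergic receptor (Rattus norvegicus); on this read-out lower numbers stand for lower potency and higher numbers for higher potency (the scale is a negative logarithm):
compound 1 `COc1cccc(OC)c1OCCNCCOc1ccccc1OCc1ccccc1Cl`: 7.52
compound 2 `COc1cccc(OC)c1OCCNCCOc1ccccc1OCc1ccc(C)cc1`: 8.43
compound 3 `COc1cccc(OC)c1OCCNCCOc1ccccc1OCc1ccccc1[N+](=O)[O-]`: 8.56

Compound 3 stands highest of the three numbers in this assay. Its nearest neighbour is compound 2, and the step of a number 0.13 log units higher from compound 2 to compound 3 (within the scatter) lies within the scatter, so the two cannot be ordered. The distant one is compound 1, and the step of a number 1.04 log units higher from compound 1 to compound 3 (beyond the scatter) is large and beyond the scatter; the step of a number 0.91 log units higher from compound 1 to compound 2 (beyond the scatter) is also beyond the scatter.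

Compound 4 `COc1cccc(COc2ccccc2OCCNCCOc2c(OC)cccc2OC)c1` is not yet measured. It differs from compound 3 in this way: 3-methoxyphenyl in place of 2-nitrophenyl on a saturated chain carbon bound to an oxygen on an aromatic ring.

Among the measured compounds shown here, the steps that bear on this change are those that vary the ring carried on the benzylic carbon. Moving from a 2-chlorophenyl to either a 4-methylphenyl or a 2-nitrophenyl raised the value by roughly a whole unit, while the exchange of 4-methylphenyl for 2-nitrophenyl made no difference beyond the scatter. For the measured compounds named here, no measured compound carries a 3-methoxyphenyl, so the direction for compound 4 is uncertain; the two ring variants other than the chloro case sit close together, and a value near that of compound 3, or somewhat lower, is expected, with a wider range to allow for a drop of the size seen with compound 1. For compound 4 the step is expected to be a number 0.26 log units lower from compound 3 to compound 4 (within the scatter). The expected value of compound 4 in this assay is 8.3, with a range from 7.6 to 8.9.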

Compound 4, negative logarithm of the antagonist equilibrium constant: 8.31
Estimate against measurement, compound 4: 0.01 log units below, within the range that was stated.
By their numbers in this assay, from the lowest: compound 1; then compounds 4, 2 and 3 (each within the scatter of the next).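

In this assay, the 3-methoxyphenyl on a saturated chain carbon bound to an oxygen on an aromatic ring falls in with the two higher variants, with a number 0.25 log units lower from compound 3 to compound 4 (within the scatter) and a number 0.12 log units lower from compound 2 to compound 4 (within the scatter), so compounds 2, 3 and 4 cannot be ordered even though three differently substituted rings are now compared at this position. Only the 2-chlorophenyl of compound 1 stands apart, now also by a number 0.79 log units higher from compound 1 to compound 4 (beyond the scatter), and the 2-nitrophenyl of compound 3 goes against any reading that a 2-substituted ring as such gives the low value. Nothing available here explains why compound 1 separates or why the other three stay together.

On these data alone, whether the chloro group or its place on the ring sets compound 1 apart remains open, and the 3-chlorophenyl, 4-chlorophenyl and 2-methoxyphenyl variants would separate the two. Also open, as far as these compounds go, is how far this position tolerates other kinds of group, such as an unsubstituted phenyl, a pyridine ring, or a ring bearing an amine or a carboxylic acid.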